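This account rests on a few compounds, and the source may have more. Where it says the series, first, only, none or still open, it means among the compounds named here.

Of the compounds shown here, three have so far been measured in a functional assay on MCF7 cells (Homo sapiens) for cytotoxicity, read by MTT assay, with a stated time of 72 h; a lower number here means a stronger inhibitor of growth, a higher number a weaker inhibitor of growth. Compound 1, `CCCOC(=O)Nc1ccc([Se]C#N)cc1`, gives 34400 nM. Compound 2, `CCCCOC(=O)Nc1ccc([Se][Se]c2ccc(NC(=O)OCCCC)cc2)cc1`, gives 46300 nM, and compound 3, `O=C(Nc1ccc([Se][Se]c2ccc(NC(=O)Oc3ccccc3)cc2)cc1)Oc1ccccc1`, gives 36700 nM. The number for compound 1 lies within the usual scatter of both other numbers, so on these data the three compounds cannot be told apart. Compound 4, `CC(C)COC(=O)Nc1ccc([Se]C#N)cc1`, has not yet been measured. It differs from compound 1 by a single change: methyl in place of hydrogen on a saturated chain carbon bound to two saturated chain carbons. Going by the values given here, no pair of measured compounds shows a step of this kind, so there is no measured guide to its size. A step of a 1.0-fold higher number from compound 1 to compound 4 (0.01 log units; within the scatter) is expected, not beyond the scatter in either direction. Compound 4 is therefore expected to give about 35000 nM, between 15000 nM and 80000 nM.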

Compound 4, concentration for total growth inhibition: 45500 nM
Compound 4: middle estimate off by 1.3-fold (0.11 log units), on the low side, within the range that was stated.
By their numbers in this assay, from the lowest: compounds 1, 3, 4 and 2 (each within the scatter of the next).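

In this assay, going by these compounds alone, the change from propoxy to isobutoxy gives a 1.3-fold higher number from compound 1 to compound 4 (0.12 log units; within the scatter) as the first measured step at this saturated chain carbon. Within the data shown here, on this one pair, methyl and hydrogen at this place cannot be told apart, so the single branch leaves the number within the scatter of compound 1. Nothing measured here explains the size of this step.

Still open, going by these compounds, is whether a larger group at this carbon, such as cyclohexyl, would move the number beyond the scatter. An amine or a carboxylic acid on the chain is equally untested by these compounds.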